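Swapping a Bromo for a Nitro Group on the Aryl Ring

The source may hold more compounds than are shown below. What is called first, only, known or untested is meant among the compounds shown, and "the series" means these compounds.

Measured compounds:
compound 1, `CCCCCCCCCCCCCCCCCCNC(=O)[C@H]1CSC(c2cccnc2)N1`, 3600 nM
compound 2, `CCCCCCCCCCCCCCCCCCNC(=O)[C@H]1CSC(c2ccc(Br)cc2)N1`, 5100 nM

Two compounds share one core and differ only in the aromatic group attached to a saturated ring carbon. In a functional assay on LNCaP cells (Prostate gland, Homo sapiens) for antiproliferative activity, read by sulforhodamine B assay (on this read-out higher numbers stand for weaker inhibition and lower numbers for stronger inhibition), compound 1 gives 3600 nM, and compound 2 gives 5100 nM. Among the compounds with values here, the only measured step, a 1.4-fold higher number from compound 1 to compound 2 (0.15 log units; within the scatter), swaps a pyridin-3-yl for a 4-bromophenyl; compound 2 therefore stands at the higher of the two numbers, yet the gap to compound 1 is within the scatter, so no order between them can be claimed.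

Compound 3, `CCCCCCCCCCCCCCCCCCNC(=O)[C@H]1CSC(c2ccc([N+](=O)[O-])cc2)N1`, is not yet measured. It differs from compound 2 by nitro in place of bromo on an aromatic carbon, placed para to a large group. Within the data shown here, no measured step changes a substituent on the aromatic ring itself; the step from compound 1 to compound 2 replaced the whole ring and produced no shift beyond the scatter. On that thin basis, the expected step is a 1.0-fold lower number from compound 2 to compound 3 (0.01 log units; within the scatter), that is, no change beyond the scatter in either direction. Compound 3 is therefore expected to give about 5000 nM in this assay, with a range from 2500 nM to 10000 nM.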

Compound 3, half-maximal inhibitory concentration: 8400 nM
For compound 3 the middle estimate is 1.7-fold (0.23 log units) below the measured one; measured number inside the range.
By their numbers in this assay, from the lowest: compounds 1, 2 and 3 (each within the scatter of the next, the first and the last beyond it).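

In this assay, within the data shown here, this is the first change made to a substituent on the aromatic ring itself rather than to the whole ring: nitro in place of bromo, para to a large group, gives a 1.6-fold higher number from compound 2 to compound 3 (0.22 log units; within the scatter) and so cannot be said to shift the number. This swap brings more heavy atoms and hydrogen-bond acceptors onto the ring, yet the read-out does not separate the two groups at this position. The replacement of the whole ring does reach a measurable difference, however, with a 2.3-fold higher number from compound 1 to compound 3 (0.37 log units; beyond the scatter) marking a modest loss of inhibition for 4-nitrophenyl in place of pyridin-3-yl, while compound 2 remains within the scatter of both neighbours, so the three compounds do not form three clearly separate levels.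

From the compounds shown here alone, it remains open whether an amine, a carboxylic acid or a methoxy group on the same aromatic carbon would leave the number just as unmoved, or would pull it clearly away from those of compound 2 and compound 3. No measurement here accounts for the modest gap between the pyridin-3-yl and 4-nitrophenyl compounds.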